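Methyl on the phenyl of compound 1

The source may hold more compounds than are shown below. What is called first, only, known or untested is meant among the compounds shown, and "the series" means these compounds.

In a functional assay on thoracic aorta (Rattus norvegicus, strain Wistar), with a stated time of 15 min (on this read-out higher numbers stand for an effect only at larger amounts of compound and lower numbers for an effect already at smaller amounts), compound 1 (`CC(C)Oc1ccc(Br)cc1C(C)NC(=O)N(C)S(=O)(=O)c1ccccc1`) gives 32100 nM. Compound 2 (`CCOc1ccc(F)cc1C(C)NC(=O)N(C)S(=O)(=O)c1ccc(Cl)cc1`) gives 24500 nM, within the scatter of compound 1. Compound 3 (`CCOc1ccc(Cl)cc1C(C)NC(=O)N(C)S(=O)(=O)c1ccc(Cl)cc1`) gives 14600 nM, a lower number than compound 1, beyond the scatter. Compound 4 (`Cc1ccc(S(=O)(=O)N(C)C(=O)NC(C)c2cc(Br)ccc2OC(C)C)cc1`) is compound 1 with methyl in place of hydrogen on an aromatic carbon, para to a large group: methyl in place of hydrogen on an aromatic carbon. Going by the values given here, the only measured step, a 1.7-fold lower number from compound 2 to compound 3 (0.22 log units; within the scatter), is a different change, chloro in place of fluoro, and stays within the scatter. Among the compounds with values here, no measured step covers phenyl to 4-methylphenyl, so no shift beyond the scatter is expected. The expected step is a 1.1-fold lower number from compound 1 to compound 4 (0.06 log units; within the scatter). Compound 4 is estimated at 28000 nM, with an expected range of 13000 nM to 60000 nM.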

Compound 4, half-maximal effective concentration: 34700 nM
Beside the measured number, compound 4's estimate is 1.2-fold (0.09 log units) below it; the range from low to high includes it.
By their numbers in this assay, from the lowest: compounds 3, 2, 1 and 4 (each within the scatter of the next, the first and the last beyond it).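

In this assay, going by these compounds alone, phenyl to 4-methylphenyl gives a 1.1-fold higher number from compound 1 to compound 4 (0.03 log units; within the scatter), the first measured step at this position of the core of compound 1. This single added carbon, on an aromatic carbon para to a large group, therefore produces no shift beyond the scatter. No supporting measurement bears on why this step is so small.

Going by these compounds, whether an amine, a carboxylic acid or a longer chain at this place would move the number remains open. A single methyl does not show how much change this position tolerates.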